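Methoxy added to a diarylpropane: cytotoxicity notes

This account rests on a few compounds, and the source may have more. Where it says the series, first, only, none or still open, it means among the compounds named here.

The set holds compound 1 `COc1ccc(CCCc2ccc(OC)c(OC)c2)c(O)c1` and compound 2 `COc1ccc(CCC(=O)c2ccc(OC)c(OC)c2)cc1O`, both measured. In an ADME assay on RAW264.7 cells (Mus musculus) for cytotoxicity, read by MTT assay, with a stated time of 24 h, tested at 1.25 ug/mL (a higher number here means a weaker effect of the compound at the concentration tested, a lower number a stronger effect), compound 1 gives 97.9%, the highest of the two numbers. In this assay compound 2 gives 95.6%, the nearest number, and the gap to compound 1 lies within the usual scatter, so the two are not told apart here. Within the data shown here, no step between compounds that differ in one place is available.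

The next compound, compound 3 `COc1ccc(CCCc2ccc(OC)c(OC)c2OC)c(O)c1`, differs from compound 1 in one place: methoxy in place of hydrogen on an aromatic carbon. Among the measured compounds shown here, with no single-place step measured, the expectation rests on compound 1 giving 97.9% and compound 2 giving 95.6% in this assay. The step from compound 1 to compound 3 is expected to be a number 1.9 percentage points lower from compound 1 to compound 3 (within the scatter), none beyond the scatter in either direction. Compound 3 is therefore estimated at 96% in this assay, with a range from 86% to 103%.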

Compound 3, a percentage reported as activity, at one concentration (the size of the read-out at that concentration, not a potency): 96.3%
For compound 3 the middle estimate is 0.3 percentage points below the measured one; measured number inside the range.
By their numbers in this assay, from the lowest: compounds 2, 3 and 1 (each within the scatter of the next).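

In this assay, methoxy in place of hydrogen on an aromatic carbon gives a number 1.6 percentage points lower from compound 1 to compound 3 (within the scatter) and so cannot be told apart from no change at this concentration. Among these compounds, this is the first single-place step: it shows that the carbon ortho to a large group, ortho to a methoxy group and meta to a methoxy group carries the added methoxy with no read-out separable from that of compound 1. No measured evidence on the cause of this step is available.

Open, going by these compounds, is whether an amine, a carboxylic acid or a longer chain at this same carbon would give a step beyond the scatter. Also open, on these data alone, is whether the methoxy step stays within the scatter at other ring carbons or at higher concentrations.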